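The compounds below may be only part of what the source reports. "The series", "measured", "known", "first", "only" and "open" are said of these compounds alone.

For the measured compounds named here, compound 1 `COc1cc(Cl)cc(-c2nn(-c3cccc(NC(=O)c4ccc(Cl)c(Cl)c4)c3)cc2-c2ccncc2)c1` is one of two compounds measured in a functional assay on U-251 cells (Homo sapiens) for inhibition, read by sulforhodamine B assay, with a stated time of 48 h, tested at 10 uM; a lower number here means a stronger effect, a higher number a weaker effect of the compound at the concentration tested; in that assay compound 1 gives 64.1%, the higher of the two numbers. Compound 2 `COc1cc(Cl)cc(-c2nn(-c3cccc(NC(=O)Nc4cc(C(F)(F)F)cc(C(F)(F)F)c4)c3)cc2-c2ccncc2)c1`, which shares the core, gives -58% in this assay. Going by the values given here, no single-point step between these two has been worked out. Compound 3 `COc1cc(Cl)cc(-c2nn(-c3cccc(NC(=O)Nc4ccc(Cl)c(Cl)c4)c3)cc2-c2ccncc2)c1` differs from compound 1 by (3,4-dichlorophenyl)amino in place of 3,4-dichlorophenyl on a carbonyl carbon. Since compound 2, which also carries a carbamoyl linkage, gives -58%, a sizeable downward step in this assay is expected. Compound 3 is estimated at 10%, between -40% and 60%, an expected step of a number 54.1 percentage points lower from compound 1 to compound 3 (beyond the scatter).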

Compound 3, a percentage reported as activity, at one concentration (the size of the read-out at that concentration, not a potency): 3.01%
Compound 3: the middle estimate sits 7 percentage points above what was measured, and the stated range covers the measured number.
By their numbers in this assay, from the lowest: compound 2; then compound 3; then compound 1.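

In this assay, (3,4-dichlorophenyl)amino in place of 3,4-dichlorophenyl on a carbonyl carbon gives a number 61.1 percentage points lower from compound 1 to compound 3 (beyond the scatter) and so isolates this one change, which the earlier pair could not do. With the rest of compound 3 the same as compound 1, the step belongs to this place alone, where a nitrogen and a hydrogen-bond donor enter. Nothing at hand explains the size of this step.

The compounds shown leave open how an N-methyl amine or an oxygen atom in place of this nitrogen would read. They also leave open whether the step would recur with a different aryl group on the same linkage.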